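A Methyl Added to Compound 3

The compounds below may be only part of what the source reports. "The series", "measured", "known", "first", "only" and "open" are said of these compounds alone.

Measured in a functional assay on cells (Melanoma cell, Homo sapiens) for inhibition; a higher number here means a weaker inhibitor of growth, a lower number a stronger inhibitor of growth:
- Compound 1 `Cc1cc(-c2nc3sc(C)cn3c2/C=N/NC(=N)N)c(C)s1`: 7410 nM
- Compound 2 `Cc1cn2c(/C=N/NC(=N)N)c(-c3ccsc3)nc2s1`: 8130 nM
- Compound 3 `N=C(N)N/N=C/c1c(-c2cccs2)nc2sccn12`: 15100 nM

Compound 3 lies within the scatter of compound 2 but beyond it from compound 1, which has the lower number. Compound 4 `Cc1cn2c(/C=N/NC(=N)N)c(-c3cccs3)nc2s1` differs from compound 3 by methyl in place of hydrogen on an aromatic carbon. For the measured compounds named here, the only measured step, a 1.1-fold higher number from compound 1 to compound 2 (0.04 log units; within the scatter), lies within the scatter and concerns another group, so it does not measure this change. Compound 2, which carries the same methyl, gives 8130 nM. A modest move toward a lower number, within the scatter, is therefore expected: a 1.5-fold lower number from compound 3 to compound 4 (0.18 log units; within the scatter). For compound 4 the estimated value in this assay is 10000 nM, with an expected range of 5000 nM to 20000 nM.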

Compound 4, concentration for 50% growth inhibition: 2240 nM
For compound 4 the middle estimate is 4.5-fold (0.65 log units) above the measured one, and the stated range ends above it.
By their numbers in this assay, from the lowest: compound 4; then compounds 1, 2 and 3 (each within the scatter of the next, the first and the last beyond it).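

In this assay, methyl in place of hydrogen on the aromatic carbon next to the ring sulfur brings a clear gain when thiophen-2-yl is present (a 6.7-fold lower number from compound 3 to compound 4 (0.83 log units; beyond the scatter)). With that methyl kept, the attached thiophene also counts: thiophen-2-yl in place of thiophen-3-yl (a 3.6-fold lower number from compound 2 to compound 4 (0.56 log units; beyond the scatter)) and in place of 2,5-dimethylthiophen-3-yl (a 3.3-fold lower number from compound 1 to compound 4 (0.52 log units; beyond the scatter)) both lower the number beyond the scatter. No evidence here bears on what lies behind these steps. Open, from the compounds shown here alone, is how this carbon responds to ethyl, an amine or a carboxylic acid in place of the methyl.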